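Swapping Carboxy for Hydroxymethyl on the Amide Chain

The source may report more compounds than this note shows. Statements on the series, on what has been measured and on what is new or still open speak of the compounds shown alone.

Compound 1 (`CCn1c(C(=O)NCCN(C)C)ccc1C(CC)(CC)c1ccc(OCCC(O)(CC)CC)c(C)c1`) and compound 2 (`CCn1c(C(=O)N(C)CC(=O)O)ccc1C(CC)(CC)c1ccc(OCCC(O)(CC)CC)c(C)c1`) share one core and differ only in the group on the amide carbonyl carbon. In a functional assay on MCF7 cells (Homo sapiens) for antiproliferative activity, read by MTT assay, with a stated time of 48 h (a lower number here means a stronger inhibitor, a higher number a weaker inhibitor), compound 1 gives 430 nM while compound 2 gives 79 nM and so holds the lower of the two numbers. Compound 3 (`CCn1c(C(=O)N(C)CCO)ccc1C(CC)(CC)c1ccc(OCCC(O)(CC)CC)c(C)c1`) has hydroxymethyl in place of carboxy on a saturated chain carbon bound to an amide-type nitrogen. Among the measured compounds shown here, the one measured step that bears on this (a 5.4-fold lower number from compound 1 to compound 2 (0.74 log units; beyond the scatter)) brought the carboxy in while replacing a whole amino group, and it is modest but beyond the scatter. For the measured compounds named here, removing the carboxy is a smaller change, so a smaller step back towards a higher number is expected (a 1.9-fold higher number from compound 2 to compound 3 (0.28 log units; within the scatter)) with much uncertainty, since only one step guides it. Compound 3 is estimated at 150 nM in this assay (range 50 nM to 450 nM) for now.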

Compound 3, half-maximal inhibitory concentration: 2870 nM
Compound 3: middle estimate off by 19-fold (1.28 log units), on the low side; the measured number lies above the stated range.
By their numbers in this assay, from the lowest: compound 2; then compound 1; then compound 3.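

In this assay, the carboxy on this saturated chain carbon bound to an amide-type nitrogen matters far more than the earlier pair could show: hydroxymethyl in its place gives a 36-fold higher number from compound 2 to compound 3 (1.56 log units; beyond the scatter), even though both groups count 1 hydrogen-bond donor, 1 hydrogen-bond acceptor and no net charge. The (2-hydroxyethyl)(methyl)amino group also falls behind the (2-(dimethylamino)ethyl)amino group, with a 6.7-fold higher number from compound 1 to compound 3 (0.82 log units; beyond the scatter), so among these three compounds the order at this place runs from carboxymethyl through the amine chain to 2-hydroxyethyl. Nothing at hand explains why this small change in atoms carries such a large step.

As far as these compounds go, how a methyl ester or a primary amide would compare with carboxy at this place remains open. So does the effect of a longer chain carrying the carboxylic acid.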